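Trading an Ether Linker for a Thioether

The compounds below may be only part of what the source reports. "The series", "measured", "known", "first", "only" and "open" are said of these compounds alone.

Of the compounds shown here, three sharing one core have been measured in a functional assay on UACC-257 cells (Homo sapiens) for inhibition, read by sulforhodamine B assay, with a stated time of 48 h; on this read-out higher numbers stand for weaker inhibition of growth and lower numbers for stronger inhibition of growth. Compound 1 `Nc1cc(N)c2nc(-c3ccccc3)c(Oc3ccc(Cl)c(Cl)c3)nc2c1` gives 87100 nM, the highest number among the three. Compound 2 `Nc1cc(N)c2nc(-c3ccccc3)c(NCc3ccc(Cl)c(Cl)c3)nc2c1` gives 15800 nM, and compound 3 `CCOC(=O)[C@H](CCC(=O)O)NC(=O)c1ccc(Sc2nc3cc(N)cc(N)c3nc2-c2ccccc2)cc1` gives 40700 nM; both numbers lie beyond the usual scatter below that of compound 1, so compound 1 shows the weakest growth inhibition of this small set.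

The next compound, compound 4 `Nc1cc(N)c2nc(-c3ccccc3)c(Sc3ccc(F)cc3)nc2c1`, is made from compound 1 by a single change: (4-fluorophenyl)sulfanyl in place of 3,4-dichlorophenoxy on an aromatic carbon. The group that leaves is the 3,4-dichlorophenoxy, and the group that enters is the (4-fluorophenyl)sulfanyl, at the same place on an aromatic carbon next to the ring nitrogen and ortho to a phenyl group.

Within the data shown here, no directly measured pair shows how this exact swap plays out. Compound 3 also carries a sulfur-linked aryl group, and its value 40700 nM sits below that of compound 1, which hints at the direction. The step of a 2.2-fold lower number from compound 1 to compound 4 (0.34 log units; beyond the scatter) is expected to be a modest drop in number, near the edge of the scatter. Compound 4 is therefore estimated at 40000 nM, within a range from 15000 nM to 100000 nM.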

Compound 4, concentration for total growth inhibition: 31600 nM
The estimate for compound 4 lay 1.3-fold (0.10 log units) above the measured number; low and high end bracket the measured number.
By their numbers in this assay, from the lowest: compounds 2, 4 and 3 (each within the scatter of the next, the first and the last beyond it); then compound 1.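

In this assay, among these compounds, this change brings a 2.8-fold lower number from compound 1 to compound 4 (0.44 log units; beyond the scatter) and gives the first direct reading at this position, on an aromatic carbon next to the ring nitrogen and ortho to a phenyl group. With the rest of the core unchanged, the (4-fluorophenyl)sulfanyl group gives modestly stronger growth inhibition than the 3,4-dichlorophenoxy group, so the group at this position does affect the read-out. No measurement at hand accounts for this shift.

On these data alone, the swap alters the linking atom and the halogens on the ring in one step, so the share of each remains unknown. A (3,4-dichlorophenyl)sulfanyl group or a 4-fluorophenoxy group at this position would separate the two, while a plain amino group would test whether an aryl ring is needed here at all.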